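Urea in place of the amide on the shared core

A few compounds are considered here, and "the series" means these few. Any claim that something is new, unique, unknown or untested is made for them only; others in the source may bear on it.

Compound 1 `COC(=O)c1ccc2cc(C(O)(c3c[nH]cn3)C(C)C)ccc2c1` is the reference point of this short series: in an assay on isolated protein for inhibition of steroid 17-alpha-hydroxylase/17,20 lyase (Homo sapiens) (on this read-out higher numbers stand for weaker inhibition and lower numbers for stronger inhibition), compound 1 gives 24 nM. Compound 2 `CCNC(=O)c1ccc2cc(C(O)(c3c[nH]cn3)C(C)C)ccc2c1` carries an ethylamide where compound 1 carries a methyl ester; in this assay compound 2 gives 46 nM. Among the compounds with values here, the only measured step, a 1.9-fold higher number from compound 1 to compound 2 (0.28 log units; within the scatter), is within the scatter, so the two numbers cannot be ordered; compound 2 sits with compound 1 in the same band, the pair being all that is known here.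

Compound 3 `CNC(=O)Nc1ccc2cc(C(O)(c3c[nH]cn3)C(C)C)ccc2c1` is not yet measured. It differs from compound 2 in one place: (methylcarbamoyl)amino in place of ethylcarbamoyl on an aromatic carbon. Within the data shown here, the one measured step that bears on this change is the amide for ester swap from compound 1 to compound 2, which reworked the group on the same aromatic carbon and moved the number only within the scatter. Among the measured compounds shown here, the urea of compound 3 is a further variation at that position, and no measured step suggests a large move in either direction.

Compound 3 is therefore expected to give roughly 50 nM in this assay, with a range of 18 nM to 140 nM. The expected step of a 1.1-fold higher number from compound 2 to compound 3 (0.04 log units; within the scatter) is estimated to stay within the scatter.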

Compound 3, half-maximal inhibitory concentration: 36 nM
For compound 3 the middle estimate is 1.4-fold (0.14 log units) above the measured one, within the range that was stated.
By their numbers in this assay, from the lowest: compounds 1, 3 and 2 (each within the scatter of the next).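

The urea result extends what the ester and amide pair showed: in this assay, the group on this aromatic carbon can also be attached through nitrogen rather than through a carbonyl carbon, with (methylcarbamoyl)amino bringing 2 hydrogen-bond donors where ethylcarbamoyl has 1, and the reading still gives a 1.3-fold lower number from compound 2 to compound 3 (0.11 log units; within the scatter). Against the methoxycarbonyl of the reference compound the reading gives a 1.5-fold higher number from compound 1 to compound 3 (0.18 log units; within the scatter), so all three groups sit in one band and cannot be ordered, with no compound of the three going against this. Nothing available explains why these groups read alike.

Still open, as far as these compounds go, is whether a carboxylic acid or a plain amine on this aromatic carbon, or a longer chain on the urea nitrogen, would stay within this band or leave it. From the compounds shown here alone, all three compounds also share the rest of the core, so the response of this assay to a change anywhere else on it remains unknown.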